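Replacing 2-phenylethenyl with furan-2-yl in compound 3

The source may report more compounds than this note shows. Statements on the series, on what has been measured and on what is new or still open speak of the compounds shown alone.

Compound 1 `COc1ccc(COc2cc(O)c3c(=O)cc(C)oc3c2[C@H]2CCN(C)C[C@H]2O)cc1`: 35%
Compound 2 `Cc1cc(=O)c2c(O)cc(OCc3ccc(Br)cc3)c([C@H]3CCN(C)C[C@H]3O)c2o1`: 17%
Compound 3 `Cc1cc(=O)c2c(O)cc(OC/C=C/c3ccccc3)c([C@H]3CCN(C)C[C@H]3O)c2o1`: 18%

All three values come from a functional assay on PC-3 cells (Homo sapiens) for inhibition, read by MTT assay, with a stated time of 48 h, tested at 10 uM; a higher number here means more inhibition of growth at the concentration tested, a lower number less inhibition of growth. Compound 3 stands level with compound 2, and the data show a number 1 percentage points higher from compound 2 to compound 3 (within the scatter). Compound 1 stands clear of both, with a number 17 percentage points lower from compound 1 to compound 3 (beyond the scatter) and a number 18 percentage points lower from compound 1 to compound 2 (beyond the scatter).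

Compound 4 `Cc1cc(=O)c2c(O)cc(OCc3ccco3)c([C@H]3CCN(C)C[C@H]3O)c2o1` keeps the shared core and carries furan-2-yl in place of 2-phenylethenyl on a saturated chain carbon bound to an oxygen on an aromatic ring.

Within the data shown here, no measured step involves furan-2-yl, so the evidence is indirect. The two steps that end at compound 3 change the same place. One of them stays within the scatter, while the other shows that a change here can move the number by a modest amount. Only compound 1 reaches the higher level, so the expectation stays near compound 3 and compound 2, with more room upward than downward. No step beyond the scatter is expected in this assay, and the expected step is a number 3 percentage points higher from compound 3 to compound 4 (within the scatter). For compound 4 the estimated value is 21%, with an expected range from 8% to 36%.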

Compound 4, percent growth inhibition at one concentration: 14%
Compound 4: middle estimate off by 7 percentage points, on the high side; measured number inside the range.
By their numbers in this assay, from the lowest: compounds 4, 2 and 3 (each within the scatter of the next); then compound 1.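

In this assay, changing a six-membered aromatic ring of carbon only, reached through the 3-phenylprop-2-en-1-yl chain, to a five-membered aromatic ring with one hetero atom leaves the number at the same low level, with a number 4 percentage points lower from compound 3 to compound 4 (within the scatter) and a number 3 percentage points lower from compound 2 to compound 4 (within the scatter) as the two readings. The gap to the 4-methoxyphenyl group also holds for this new group (a number 21 percentage points lower from compound 1 to compound 4 (beyond the scatter)), so 4-bromophenyl, 2-phenylethenyl and furan-2-yl now form a set of three different groups within the scatter of one another at this place, and 4-methoxyphenyl alone stands apart from them. Nothing in the data given explains why that one group differs from the other three.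

Going by these compounds, it remains open whether the higher number of compound 1 belongs to the methoxy group itself, or whether a 4-ethoxyphenyl or 4-hydroxyphenyl group in the same place would reach that level too. How a group carrying an amine or a carboxylic acid, or a plain longer alkyl chain, would read at this place is also left open by these compounds.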